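This account rests on a few compounds, and the source may have more. Where it says the series, first, only, none or still open, it means among the compounds named here.

Measured so far in a functional assay on HUVEC cells (Homo sapiens); a lower number here means that less compound is needed, a higher number that more compound is needed for the effect:

- compound 1 `Cc1c(O)c(C)c2c(c1O)C(=O)CC(c1ccccc1O)O2`: > 20000 nM
- compound 2 `Cc1c(O)c(C)c2c(c1O)C(=O)CC(c1cccc(O)c1)O2`: > 20000 nM
- compound 3 `Cc1c(O)c(C)c2c(c1O)C(=O)CC(c1ccc([N+](=O)[O-])cc1)O2`: > 20000 nM

Compound 1 stands at > 20000 nM, which is a limit of the assay and not a number. Every reading so far is of this kind: the limit of > 20000 nM in this assay, at which 3 of the 3 values shown sit. None of the three compounds therefore has an exact value to compare.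

The next compound to be tested is compound 4 `Cc1c(O)c(C)c2c(c1O)C(=O)CC(c1ccccc1[N+](=O)[O-])O2`, which keeps the core of compound 1 and changes one group: nitro in place of hydroxy on an aromatic carbon. Nitro takes the place of hydroxy on an aromatic carbon of a six-membered aromatic ring of carbon only, ortho to a large group.

Two measurements bear on this change. Among the compounds with values here, the only measured step is a step that the two limits leave unreadable from compound 1 to compound 2, so it offers no size to carry over. Compound 3, which also carries a nitro group, reads > 20000 nM, again only a limit.

With no readable step to build on, no clear step in either direction is expected in this assay, and compound 4 will most likely be reported only as a limit too. The expected step is a step that the limit leaves unreadable from compound 1 to compound 4. For compound 4 the estimated value is 30000 nM, with an expected range of 12000 nM to 60000 nM.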

Compound 4, half-maximal effective concentration: > 5000 nM
Compound 4: a limit, no number; the forecaster's own chance of this, stated with the estimate: 85%; the middle value lies beyond the limit too.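

In this assay compound 4 gives > 5000 nM, which is a limit of the assay and not a number. Compound 1 is also known only as a limit, so the step between compound 1 and compound 4 cannot be read. The compounds shown leave open how much of any of them is needed for the effect, and whether nitro in place of hydroxy changes that amount at all.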